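Amide cap change on the anilide: isopropyl to phenyl

This account rests on a few compounds, and the source may have more. Where it says the series, first, only, none or still open, it means among the compounds named here.

Measured so far:
compound 1 `CC1CCN(c2nc(C(F)(F)F)ccc2CNC(=O)C(C)c2ccc(Nc3ccc(Cl)cc3)cc2)CC1`, 66.5 nM
compound 2 `CC1CCN(c2nc(C(F)(F)F)ccc2CNC(=O)C(C)c2ccc(NC(=O)C(C)C)c(F)c2)CC1`, 26.4 nM

Both numbers come from an assay on cells for antagonist activity at transient receptor potential cation channel subfamily V member 1 (Homo sapiens), read by FLIPR and calcium flux, with a stated time of 6 min; on this read-out higher numbers stand for weaker inhibition and lower numbers for stronger inhibition. Compound 2 stands lowest of the two, with compound 1 at a higher number, beyond the scatter. Compound 3 `CC1CCN(c2nc(C(F)(F)F)ccc2CNC(=O)C(C)c2ccc(NC(=O)c3ccccc3)c(F)c2)CC1` differs from compound 2 in one place: phenyl in place of isopropyl on a carbonyl carbon. Among the compounds with values here, no measured pair shows this step, so its size is open; from compound 2 at 26.4 nM a change within or slightly beyond the scatter in either direction is expected, with no firm direction. The expected step is a 1.1-fold higher number from compound 2 to compound 3 (0.06 log units; within the scatter). Compound 3 is estimated at 30 nM, range 10 nM to 90 nM, in this assay.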

Compound 3, inhibition constant: 7.4 nM
Beside the measured number, compound 3's estimate is 4.1-fold (0.61 log units) above it; measured number below the stated range.
By their numbers in this assay, from the lowest: compound 3; then compound 2; then compound 1.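

In this assay, phenyl in place of isopropyl on a carbonyl carbon gives a 3.6-fold lower number from compound 2 to compound 3 (0.55 log units; beyond the scatter). This is the only single-place step shown, and it shows that this position accepts a six-membered aromatic ring of carbon only, with a number lower beyond the scatter. No measurement shown gives a reason for this step.

From the compounds shown here alone, it remains open whether a ring is needed at all, since a cyclohexyl group or a longer chain on the carbonyl carbon would test that. Going by these compounds, whether a pyridyl ring or a chloro-substituted benzoyl keeps the gain is also open.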